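From Fluoro to Trifluoromethyl at the Amide End

The source may hold more compounds than are shown below. What is called first, only, known or untested is meant among the compounds shown, and "the series" means these compounds.

Measured so far:
Compound 1, `CN(C)C(=O)c1cc2cnc(Nc3ccc(NC(=O)C4(C(=O)Nc5ccc(F)cc5)CC4)cc3)nc2n1C1CCCC1`: 102%
Compound 2, `CN(C)C(=O)c1cc2cnc(Nc3ccc(NC(=O)C4(C(=O)Nc5cccc(C#N)c5)CC4)cc3)nc2n1C1CCCC1`: 73.6%

Both numbers come from a functional assay on A549 cells (Homo sapiens) for inhibition, read by CCK-8 assay, with a stated time of 72 h, tested at 10 uM; on this read-out higher numbers stand for more inhibition of growth at the one concentration tested and lower numbers for less inhibition of growth. Compound 1 stands highest of the two values; its nearest neighbour is compound 2, reached by a number 28.4 percentage points lower from compound 1 to compound 2 (beyond the scatter) through 3-cyanophenyl in place of 4-fluorophenyl on an amide-type nitrogen.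

Compound 3, `CN(C)C(=O)c1cc2cnc(Nc3ccc(NC(=O)C4(C(=O)Nc5ccc(C(F)(F)F)cc5)CC4)cc3)nc2n1C1CCCC1`, has not yet been tested. It differs from compound 1 by trifluoromethyl in place of fluoro on an aromatic carbon. Among the measured compounds shown here, no measured step alters this position alone; the one step available, a number 28.4 percentage points lower from compound 1 to compound 2 (beyond the scatter), changes both the group and its place on the ring, so it shows only that reworking this phenyl ring can lower growth inhibition modestly. A smaller shift is expected here. Compound 3 is estimated at 90%, within a range from 65% to 105%. This estimate means a number 12 percentage points lower from compound 1 to compound 3 (beyond the scatter) is expected, a drop not clearly beyond the scatter.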

Compound 3, percent growth inhibition at one concentration: 87.9%
Estimate against measurement, compound 3: 2.1 percentage points above, within the range that was stated.
By their numbers in this assay, from the lowest: compound 2; then compound 3; then compound 1.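

With the place on the ring held fixed, trifluoromethyl in place of fluoro gives a number 14.1 percentage points lower from compound 1 to compound 3 (beyond the scatter) in this assay, so changing the group alone, without moving it, is enough to lower growth inhibition. Putting 4-(trifluoromethyl)phenyl in place of 3-cyanophenyl gives a number 14.3 percentage points higher from compound 2 to compound 3 (beyond the scatter), which places compound 3 between the other two, and compound 1 stays highest, with both of its steps beyond the scatter. No measurement shown here accounts for these differences.

The compounds shown leave open whether an amine, a carboxylic acid or a methoxy group on this same aromatic carbon would match compound 1 or fall further. They also leave open how trifluoromethyl would behave on a different carbon of this ring, and how the three compounds would compare at concentrations other than the single one tested.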